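A few compounds are considered here, and "the series" means these few. Any claim that something is new, unique, unknown or untested is made for them only; others in the source may bear on it.

Measured compounds in a functional assay on CCRF-CEM cells (Homo sapiens) for cytotoxicity, read by resazurin assay, with a stated time of 48 h; on this read-out higher numbers stand for weaker inhibition and lower numbers for stronger inhibition:
compound 1, `CCOc1ccc(NC(=O)c2c(N)n[nH]c2Nc2ccccc2)cc1`, gives 4470 nM
compound 2, `CCOc1ccc(-n2nnc3n[nH]c(Nc4ccccc4)c3c2=O)cc1`, gives 5920 nM
compound 3, `CCNc1[nH]nc(N)c1C(=O)Nc1ccc(OCC)cc1`, gives 14000 nM

Compound 2 and compound 1 carry different cores; the difference between the two cores is not broken down here, and their two values lie within the scatter of each other. Within the data shown here, the one counted change in the set is ethyl in place of phenyl on a nitrogen on an aromatic ring, which gives a 3.1-fold higher number from compound 1 to compound 3 (0.50 log units; beyond the scatter).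

Compound 4, `CCNc1[nH]nc2nnn(-c3ccc(OCC)cc3)c(=O)c12`, is not yet measured. It stands to compound 2 as compound 3 stands to compound 1: ethyl in place of phenyl on a nitrogen on an aromatic ring, the same kind of change on the core of compound 2, both place lines reading the same. The expectation rests on compound 1 and compound 3, whose step is a 3.1-fold higher number from compound 1 to compound 3 (0.50 log units; beyond the scatter), carried over to compound 2 and its value 5920 nM. A step of about a 3.0-fold higher number from compound 2 to compound 4 (0.48 log units; beyond the scatter) is therefore expected from compound 2 to compound 4. Compound 4 is estimated at 18000 nM, with a likely range from 8000 nM to 40000 nM.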

Compound 4, half-maximal inhibitory concentration: 15200 nM
The estimate for compound 4 lay 1.2-fold (0.07 log units) above the measured number, and the stated range covers the measured number.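

In this assay, ethyl in place of phenyl on a nitrogen on an aromatic ring gives a 2.6-fold higher number from compound 2 to compound 4 (0.41 log units; beyond the scatter), and the earlier step on the other core reads alike: the same change on two cores in this assay, a 3.1-fold higher number (0.50 log units; beyond the scatter) from compound 1 to compound 3 and a 2.6-fold higher number (0.41 log units; beyond the scatter) from compound 2 to compound 4, 1.2-fold (0.09 log units) apart, within the scatter of two such steps. Within this assay, the change therefore carries from one core to the other with no difference in size beyond the scatter. Among these compounds, this rests on only two pairs and two cores, so it sets no rule for any further core and gives no reason for the step.

The compounds shown leave open whether a longer chain, such as butyl, or a benzyl group on that nitrogen would also behave alike on both cores. They also leave open how far a different group in place of the ethoxy, such as a carboxylic acid or an amine, would alter the step.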